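Ethoxycarbonyl in place of trifluoromethyl, second ring position

A few compounds are considered here, and "the series" means these few. Any claim that something is new, unique, unknown or untested is made for them only; others in the source may bear on it.

Measured so far:
Compound 1, `C[C@@H](NC(=O)Nc1cccc(C(F)(F)F)c1)c1ccccc1`, in an ADME assay on the whole organism with Oryza sativa as the target, tested at 0.1 uM; a lower number here means a stronger effect, a higher number a weaker effect of the compound at the concentration tested: 82%
Compound 2, `C[C@@H](NC(=O)Nc1ccc(C(F)(F)F)cc1)c1ccccc1`, in this assay: 93%
Compound 3, `CCOC(=O)c1cccc(NC(=O)N[C@H](C)c2ccccc2)c1`, in this assay: 99%

Compound 1 and compound 2 have the same atoms joined differently; the difference between the two cores is not broken down here. Compound 2 sits closest to compound 3, a gap within the usual scatter, and further from compound 1, a gap beyond it.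

One change is seen once in the measured set: ethoxycarbonyl in place of trifluoromethyl on an aromatic carbon. Its step in this assay was a number 17 percentage points higher from compound 1 to compound 3 (beyond the scatter), a modest rise beyond the scatter.

Compound 4, `CCOC(=O)c1ccc(NC(=O)N[C@H](C)c2ccccc2)cc1`, is not yet measured. It carries the same kind of change relative to compound 2: ethoxycarbonyl in place of trifluoromethyl on an aromatic carbon. The place differs from the earlier pair in that the new group sits para to a large group rather than meta to a large group, so the two changes are alike in kind but not the same.

The step from compound 2 to compound 4 in this assay is expected to be smaller than the earlier one, a number 5 percentage points higher from compound 2 to compound 4 (within the scatter), because a number 17 percentage points higher from compound 1 to compound 3 (beyond the scatter) started from a lower number and compound 2 already stands near the top of the range. For compound 4 the expected value is 98%, with a range from 90% to 100%.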

Compound 4, a percentage reported as activity, at one concentration (the size of the read-out at that concentration, not a potency): 101%
For compound 4 the middle estimate is 3 percentage points below the measured one, outside the stated range (above it).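

In this assay, ethoxycarbonyl in place of trifluoromethyl on the core of compound 2 gives a number 8 percentage points higher from compound 2 to compound 4 (within the scatter), so on this core the change cannot be told apart from repeat-measurement noise. Set beside the step on the other core, the change shows no measurable dependence on the core, as the two steps do not separate from each other: the same change on two cores in this assay, a number 17 percentage points higher (beyond the scatter) from compound 1 to compound 3 and a number 8 percentage points higher (within the scatter) from compound 2 to compound 4, 9 percentage points apart, within the scatter of two such steps. Among these compounds, this does not show that the two steps are equal or give a reliable size for the change, since it rests on only two pairs, only one of those steps lies beyond the scatter, and the four compounds do not say what the result would be on any other core.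

Still open, from the compounds shown here alone, is how the read-out would respond to an amine, a carboxylic acid or a nitrile on the same aromatic carbon in place of ethoxycarbonyl, or to a longer chain on the ester oxygen. Among the compounds shown here, also open is whether any such group would give a number clearly lower than that of compound 1, the only compound here with a step beyond the scatter to another compound.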